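From phenyl to benzyl on a shared core

A few compounds are considered here, and "the series" means these few. Any claim that something is new, unique, unknown or untested is made for them only; others in the source may bear on it.

Measured so far in a physicochemical assay for acid dissociation:
- compound 1 `COc1cccc(CNCCCNc2ccnc3cc(Cc4cc(C)cc(C)c4)ccc23)c1O` gives 9.47
- compound 2 `COc1cccc(Oc2ccc3c(NCCCNCc4cccc(OC)c4O)ccnc3c2)c1` gives 9.28
- compound 3 `COc1cccc(CNCCCNc2ccnc3cc(-c4ccccc4)ccc23)c1O` gives 9.47

Compound 3 reads the same as compound 1, and compound 2 lies within the usual scatter of both. The next compound, compound 4 `COc1cccc(CNCCCNc2ccnc3cc(Cc4ccccc4)ccc23)c1O`, carries benzyl in place of phenyl on an aromatic carbon and is otherwise the same as compound 3.

For the measured compounds named here, three measured steps bear on this change, each swapping one group at this place on the shared core. Replacing 3,5-dimethylbenzyl with phenyl gave no change at the digits printed from compound 1 to compound 3 (within the scatter) and the two swaps involving 3-methoxyphenoxy gave a number 0.19 log units lower from compound 1 to compound 2 (within the scatter) and a number 0.19 log units higher from compound 2 to compound 3 (within the scatter) in this assay. None of these goes beyond the scatter, and the first is the closest guide since it also links a benzyl-type group with phenyl.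

The expected step is a number 0.02 log units lower from compound 3 to compound 4 (within the scatter) so no change beyond the scatter is anticipated. The estimated value for compound 4 is 9.45 and the expected range runs from 9.2 to 9.7 around it.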

Compound 4, acid dissociation constant: 9.47
The estimate for compound 4 lay 0.02 log units below the measured number; measured number inside the range.
By their numbers in this assay, from the lowest: compounds 2, 1, 3 and 4 (each within the scatter of the next).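

In this assay, benzyl in place of phenyl on an aromatic carbon gave no change at the digits printed from compound 3 to compound 4 (within the scatter), so the added carbon of benzyl leaves the number where it stood. Benzyl also matches the two larger groups at this place, with no change at the digits printed from compound 1 to compound 4 (within the scatter) for 3,5-dimethylbenzyl and a number 0.19 log units higher from compound 2 to compound 4 (within the scatter) for 3-methoxyphenoxy, and all four compounds now read alike within the scatter. Nothing available explains this flat reading.

On these data alone, all four groups carry a six-membered aromatic ring of carbon only, so it remains open whether an amine or a carboxylic acid at this place would move the number beyond the scatter. Which proton of the molecule the number describes also stays open.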